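The source may report more compounds than this note shows. Statements on the series, on what has been measured and on what is new or still open speak of the compounds shown alone.

Series notes, variation of the group on the oxygen on the aromatic ring of the shared core. Compound 1 `Nc1ccc2cccc(OC3CCCCC3)c2n1` carries cyclohexyl there; in an assay on cells with melanin-concentrating hormone receptor 1 (Homo sapiens) as the target, read by radioligand binding (on this read-out higher numbers stand for weaker inhibition and lower numbers for stronger inhibition), compound 1 gives 361 nM. Compound 2 `COCC(C)Oc1cccc2ccc(N)nc12` carries 1-(methoxymethyl)ethyl, and in this assay compound 2 gives 606 nM; the step of a 1.7-fold higher number from compound 1 to compound 2 (0.22 log units; within the scatter) is within the scatter. Compound 3 `CCC(C)COc1cccc2ccc(N)nc12` carries 2-methylbutyl, and in this assay compound 3 gives 36 nM, the lowest of the three numbers, with a 10-fold lower number from compound 1 to compound 3 (1.00 log units; beyond the scatter) and a 17-fold lower number from compound 2 to compound 3 (1.23 log units; beyond the scatter) both beyond the scatter. Compound 4 `Nc1ccc2cccc(OCC3CCCC3)c2n1` is not yet measured in this assay. Its difference from compound 3 is cyclopentyl in place of sec-butyl on a saturated chain carbon bound to an oxygen on an aromatic ring. Among the compounds with values here, the steps that bear on this change are the two into compound 3, a 10-fold lower number from compound 1 to compound 3 (1.00 log units; beyond the scatter) and a 17-fold lower number from compound 2 to compound 3 (1.23 log units; beyond the scatter), which show that what sits on the oxygen moves the number well beyond the scatter, and of these the step of a 10-fold lower number from compound 1 to compound 3 (1.00 log units; beyond the scatter) shows cyclohexyl on the oxygen giving a higher number than 2-methylbutyl. Compound 4 keeps a saturated chain carbon on the oxygen and carries its ring one bond further out, so a step of a 2.2-fold higher number from compound 3 to compound 4 (0.35 log units; beyond the scatter) is expected, smaller than a 10-fold lower number from compound 1 to compound 3 (1.00 log units; beyond the scatter) run backwards. Compound 4 is accordingly estimated at 80 nM, with a range of 25 nM to 250 nM.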

Compound 4, half-maximal inhibitory concentration: 53 nM
Beside the measured number, compound 4's estimate is 1.5-fold (0.18 log units) above it; measured number inside the range.
By their numbers in this assay, from the lowest: compounds 3 and 4 (each within the scatter of the next); then compounds 1 and 2 (each within the scatter of the next).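

In this assay the step of a 1.5-fold higher number from compound 3 to compound 4 (0.17 log units; within the scatter) is within the scatter, so cyclopentyl in place of sec-butyl on a saturated chain carbon bound to an oxygen on an aromatic ring is tolerated, and a ring in the group on the oxygen need not bring the higher number seen with cyclohexyl in compound 1. The step of a 6.8-fold lower number from compound 1 to compound 4 (0.83 log units; beyond the scatter) lies beyond the scatter, which ties that higher number to cyclohexyl sitting directly on the oxygen rather than to a ring as such, although this pair changes ring size and the saturated chain carbon together; the step of an 11-fold lower number from compound 2 to compound 4 (1.06 log units; beyond the scatter) is also beyond the scatter and leaves 1-(methoxymethyl)ethyl apart from both cyclopentylmethyl and 2-methylbutyl. Nothing shown gives a reason for any of these steps.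

Cyclohexylmethyl on the oxygen would separate the effect of ring size from that of the saturated chain carbon, and the compounds shown do not settle this. Also open, going by these compounds, is how a longer chain, a benzyl group or a ring-bearing amine such as piperidinylmethyl would fare at this place.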